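The compounds below may be only part of what the source reports. "The series", "measured", "known", "first", "only" and "open" are said of these compounds alone.

Compound 1 `CCCc1cc(C)c(C(=O)N=C(N)N)cc1S(C)(=O)=O` stands lowest among the three measured compounds in a functional assay for inhibition of sodium/hydrogen exchanger (Oryctolagus cuniculus) (a higher number here means a weaker inhibitor, a lower number a stronger inhibitor), where compound 1 gives 5.7 nM. Compound 2 `Cc1c(C(=O)N=C(N)N)cc(S(C)(=O)=O)c(C)c1C` gives 55 nM in this assay, and compound 3 `Cc1cc(Br)c(C(=O)N=C(N)N)cc1S(C)(=O)=O` gives 70 nM; both of these lie beyond the scatter above compound 1. Compound 4 `Cc1cc(SC(C)(C)C)c(S(C)(=O)=O)cc1C(=O)N=C(N)N` differs from compound 1 in one place: (tert-butyl)sulfanyl in place of propyl on an aromatic carbon. Among the compounds with values here, no pair of measured compounds isolates this change, so its effect is not anchored by a measured step. Since compound 1 gave 5.7 nM, compound 4 is expected to remain a strong inhibitor, with a modest step toward a higher number expected from compound 1 to compound 4 a 2.1-fold higher number from compound 1 to compound 4 (0.32 log units; beyond the scatter), close to the edge of the scatter. Compound 4 is therefore estimated at 12 nM, within a range of 3 nM to 50 nM.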

Compound 4, half-maximal inhibitory concentration: 22 nM
Estimate against measurement, compound 4: 1.8-fold (0.26 log units) below; low and high end bracket the measured number.
By their numbers in this assay, from the lowest: compound 1; then compound 4; then compounds 2 and 3 (each within the scatter of the next).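

In this assay, (tert-butyl)sulfanyl in place of propyl on this aromatic carbon, ortho to the methylsulfonyl group, gives a 3.9-fold higher number from compound 1 to compound 4 (0.59 log units; beyond the scatter) and so costs a modest but real amount. The position thus accepts a sulfur-linked branched group, with compound 4 still at 22 nM for a stronger inhibitor than a large loss would leave. No measured evidence explains the step. Whether the sulfur or the branching accounts for the step stays open, since neither changes alone here. From the compounds shown here alone, how an amine or a longer chain would fare at this position also stays open.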